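Regioisomeric purine ethers: phenoxy for cyclohexylmethoxy

The compounds below may be only part of what the source reports. "The series", "measured", "known", "first", "only" and "open" are said of these compounds alone.

Compound 1 `c1ccc2c(c1)COC(n1cnc3c(OCC4CCCCC4)ncnc31)CO2` and compound 3 `c1ccc2c(c1)COC(n1cnc3ncnc(OCC4CCCCC4)c31)CO2` are built from the same atoms joined differently; the difference between the two cores is not broken down here. In a functional assay on MCF7 cells (Homo sapiens) for antiproliferative activity, read by sulforhodamine B assay, with a stated time of 3 days (on this read-out lower numbers stand for stronger inhibition and higher numbers for weaker inhibition), compound 1 gives 11600 nM, and compound 3 gives 13400 nM, a gap within the scatter. Compound 2 `c1ccc(Oc2ncnc3c2ncn3C2COc3ccccc3CO2)cc1` carries the change phenyl in place of cyclohexylmethyl on an oxygen on an aromatic ring relative to compound 1, and in this assay compound 2 gives 24700 nM; the step is a 2.1-fold higher number from compound 1 to compound 2 (0.33 log units; beyond the scatter).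

Compound 4 `c1ccc(Oc2ncnc3ncn(C4COc5ccccc5CO4)c23)cc1` bears the same change relative to compound 3, namely (phenyl in place of cyclohexylmethyl on an oxygen on an aromatic ring), at a place described in the same words. Going by the values given here, the only guide is the one measured step of this kind, so compound 4 is expected to move by about a 2.0-fold higher number from compound 3 to compound 4 (0.30 log units; within the scatter) in this assay, resting on a 2.1-fold higher number from compound 1 to compound 2 (0.33 log units; beyond the scatter) in the first core. Since the two cores behave alike as far as compound 1 and compound 3 show, the estimate for compound 4 in this assay is 27000 nM, with a range from 13000 nM to 56000 nM.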

Compound 4, half-maximal inhibitory concentration: 21100 nM
Estimate against measurement, compound 4: 1.3-fold (0.11 log units) above, and the stated range covers the measured number.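

Replacing cyclohexylmethyl with phenyl on the core of compound 3 gives, in this assay, a 1.6-fold higher number from compound 3 to compound 4 (0.20 log units; within the scatter), so this step taken alone cannot be told from repeat-measurement noise. Set beside the step on the core of compound 1, it does not differ from it: the same change on two cores in this assay, a 2.1-fold higher number (0.33 log units; beyond the scatter) from compound 1 to compound 2 and a 1.6-fold higher number (0.20 log units; within the scatter) from compound 3 to compound 4, 1.4-fold (0.13 log units) apart, within the scatter of two such steps. This shows that, for these two matched pairs, the change carries from one core to the other without a detectable difference in size, but it does not show a general rule, since it rests on a single change, on two cores, in one cell assay, and one of the two steps is not distinguishable from scatter.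

What the compounds shown leave open is how other groups on that oxygen would behave, such as a benzyl group, a substituted phenyl or a longer chain ending in an amine. As far as these compounds go, it also remains open whether the two cores would still keep step with such groups in place.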